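Opening the ring amide: from compound 2 to compound 3

A few compounds are considered here, and "the series" means these few. Any claim that something is new, unique, unknown or untested is made for them only; others in the source may bear on it.

Compound 2 `COc1ccc(Cl)cc1N(CC(=O)N1CCc2ccccc21)S(=O)(=O)c1ccccc1` was tested in a functional assay on SH-SY5Y cells (Homo sapiens), read by MTT assay, with a stated time of 24 h (a higher number here means that more compound is needed for the effect, a lower number that less compound is needed), where compound 2 reaches only the assay limit of > 20000 nM, so no number is known for it. Compound 1 `COc1ccc(Cl)cc1N(CC(=O)Nc1cccc2ccccc12)S(=O)(=O)c1ccccc1` gives 17400 nM in this assay, and the move an at least 1.1-fold higher number from compound 1 to compound 2 (0.06 log units; that floor lies within the scatter) stays within the scatter. Compound 3 `COc1ccc(NC(=O)CN(c2cc(Cl)ccc2OC)S(=O)(=O)c2ccccc2)cc1` differs from compound 2 by (4-methoxyphenyl)amino in place of 2,3-dihydro-1H-indol-1-yl on a carbonyl carbon. Going by the values given here, that single measured step is the only guide, and because the limit of > 20000 nM in this assay, at which 1 of the 2 values shown sits, hides the true size of compound 2, it cannot fix a direction. A change of a number no higher from compound 2 to compound 3 (the limit leaves the size open) is therefore expected, not beyond the scatter. Compound 3 is estimated at 20000 nM, between 8000 nM and 60000 nM.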

Compound 3, half-maximal effective concentration: 16200 nM
The estimate for compound 3 lay 1.2-fold (0.09 log units) above the measured number, within the range that was stated.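

In this assay the change on the amide-type nitrogen gives a 1.1-fold lower number from compound 1 to compound 3 (0.03 log units; within the scatter) and so does not separate 4-methoxyphenyl from naphthalen-1-yl. For compound 2 the value > 20000 nM is only a limit of the assay. Replacing 2,3-dihydro-1H-indol-1-yl with (4-methoxyphenyl)amino gives an at least 1.2-fold lower number from compound 2 to compound 3 (0.09 log units; that floor lies within the scatter) and the true size of this step stays unknown because of that limit: the limit of > 20000 nM in this assay, at which 1 of the 3 values shown sits.

As far as these compounds go, whether a cyclohexyl group, or a chain ending in an amine, on the amide nitrogen would shift the number beyond the scatter stays open.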